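Removing a Methyl Group from Compound 2

A few compounds are considered here, and "the series" means these few. Any claim that something is new, unique, unknown or untested is made for them only; others in the source may bear on it.

Measured in an ADME assay on HeLa cells (Homo sapiens) for cytotoxicity, with a stated time of 72 h; on this read-out higher numbers stand for lower toxicity in this test and lower numbers for higher toxicity in this test:
- compound 1 `COc1ccc(/C=C\c2cc(OC)c(OC)c(OC)c2)cc1NC(=O)[C@H](CO)NC(=O)[C@H](CCCNC(=N)N)NC(=O)[C@H](CCCNC(=N)N)NC(=O)c1ccccc1`: 29.2 nM
- compound 2 `COc1ccc(/C=C\c2cc(OC)c(OC)c(OC)c2)cc1NC(=O)[C@H](C)NC(=O)[C@H](CCCNC(=N)N)NC(=O)[C@H](CCCNC(=N)N)NC(=O)c1ccccc1`: 65.7 nM

Of these two compounds, compound 2 has the higher number, which means lower toxicity in this test. Compound 3 `COc1ccc(/C=C\c2cc(OC)c(OC)c(OC)c2)cc1NC(=O)CNC(=O)[C@H](CCCNC(=N)N)NC(=O)[C@H](CCCNC(=N)N)NC(=O)c1ccccc1` has not been measured. It differs from compound 2 in a single place: hydrogen in place of methyl on a saturated chain carbon bound to an amide-type nitrogen and a carbonyl carbon. In words, this is hydrogen in place of methyl on a saturated chain carbon bound to an amide-type nitrogen and a carbonyl carbon.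

Among the compounds with values here, only one measured step offers guidance, a 2.3-fold higher number from compound 1 to compound 2 (0.35 log units; beyond the scatter), and it is modest. That step also put hydrogen in place of a group, though a different one at a different place, so it is only a rough guide. In this assay, a step no larger is therefore expected, probably within the scatter and with no firm direction. The expected step is a 1.1-fold lower number from compound 2 to compound 3 (0.04 log units; within the scatter). For compound 3 the estimated value is 60 nM, with an expected range from 25 nM to 150 nM.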

Compound 3, half-maximal cytotoxic concentration: 7.2 nM
Estimate against measurement, compound 3: 8.3-fold (0.92 log units) above; the measured number lies below the stated range.
By their numbers in this assay, from the lowest: compound 3; then compound 1; then compound 2.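

In this assay, this chain carbon proves far from indifferent to what it carries: replacing the methyl with hydrogen gives a 9.1-fold lower number from compound 2 to compound 3 (0.96 log units; beyond the scatter) in the half-maximal cytotoxic concentration. Putting hydrogen in place of hydroxymethyl at the same carbon points the same way, with a 4.1-fold lower number from compound 1 to compound 3 (0.61 log units; beyond the scatter) and so, of these three compounds, the one with hydrogen at this carbon shows the highest toxicity in this test. Nothing available explains why this single change has such an effect.

Still open, going by these compounds, is whether hydrogen is unique here or whether other groups on this carbon, such as an amine, a carboxylic acid or a longer chain, would give similarly low numbers. The compounds shown also leave open how the opposite spatial arrangement of the methyl would compare.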